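This account rests on a few compounds, and the source may have more. Where it says the series, first, only, none or still open, it means among the compounds named here.

Measured so far:
compound 1 `CC(C)OC(=O)C1=CN(C(=O)c2ccc(F)c(F)c2)CC(C)(C)c2cc(C#N)[nH]c21` — 6.3 nM
compound 2 `CC(C)OC(=O)C1=CN(C(=O)c2ccc(F)cc2)CC(C)(C)c2cc(C#N)[nH]c21` — 5 nM
compound 3 `CC(C)OC(=O)C1CN(C(=O)c2ccc(C#N)cc2)CC(C)(C)c2cc(C#N)[nH]c21` — 5700 nM

In an assay on HEK293 cells for agonist activity at Bile acid receptor (Homo sapiens), read by a luciferase reporter (on this read-out higher numbers stand for an effect only at larger amounts of compound and lower numbers for an effect already at smaller amounts), compound 3 stands highest of the three numbers, far beyond the scatter from compound 1 and from compound 2. Compound 4 `CC(C)OC(=O)C1CN(C(=O)c2cccc(F)c2)CC(C)(C)c2cc(C#N)[nH]c21` is not yet measured. It differs from compound 3 in one place: 3-fluorophenyl in place of 4-cyanophenyl on a carbonyl carbon.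

For the measured compounds named here, no measured pair covers this exchange. Going by the values given here, the only single-place step on record, a 1.3-fold lower number from compound 1 to compound 2 (0.10 log units; within the scatter), concerns a fluoro on an aromatic carbon and lies within the scatter; it touches the same ring but not the nitrile. Compound 3 differs from compound 1 and from compound 2 in more than one place, so their gap cannot be assigned to the aryl group alone. The expectation is therefore anchored on compound 3 with wide uncertainty.

Compound 4 is expected near 3000 nM, within 500 nM to 15000 nM, that is a step of a 1.9-fold lower number from compound 3 to compound 4 (0.28 log units; within the scatter).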

Compound 4, half-maximal effective concentration: 1300 nM
Estimate against measurement, compound 4: 2.3-fold (0.36 log units) above; low and high end bracket the measured number.
By their numbers in this assay, from the lowest: compounds 2 and 1 (each within the scatter of the next); then compound 4; then compound 3.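

In this assay, for the compounds shown here, the group on the carbonyl carbon can move the number on the core of compound 3: 3-fluorophenyl in place of 4-cyanophenyl gives a 4.4-fold lower number from compound 3 to compound 4 (0.64 log units; beyond the scatter) as a modest step, the first single-place step in this set beyond the scatter. No supporting data on hand speak to the origin of this step.

The exchange removes the nitrile and adds the fluoro together, so the share of each stays unseparated. As far as these compounds go, whether an unsubstituted phenyl, or a methoxy group or an amine on that ring, would move the number further on this core remains open.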